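Amide nitrogen substituent on the fused core, compound 3

The compounds below may be only part of what the source reports. "The series", "measured", "known", "first", "only" and "open" are said of these compounds alone.

Compound 2 `O=C1COc2ccc(-c3cnc(Cl)c(NS(=O)(=O)c4ccc(F)cc4)c3)cc2N1C1CC1` gives 21800 nM in a functional assay on A-375 cells (Homo sapiens) for antiproliferative activity, read by MTT assay, with a stated time of 72 h; a higher number here means a weaker inhibitor, a lower number a stronger inhibitor; it is the only number shown for the series. Compound 1 `O=C1COc2ccc(-c3cnc(Cl)c(NS(=O)(=O)c4ccc(F)cc4)c3)cc2N1` reaches only the assay limit, > 40000 nM, in this assay. Within the data shown here, the single measured step, an at least 1.8-fold lower number from compound 1 to compound 2 (0.26 log units; that floor lies within the scatter), rests on (the limit of > 40000 nM in this assay, at which 1 of the 2 values shown sits), so only its floor is known. Compound 3 `COc1ccc(N2C(=O)COc3ccc(-c4cnc(Cl)c(NS(=O)(=O)c5ccc(F)cc5)c4)cc32)cc1` differs from compound 2 by 4-methoxyphenyl in place of cyclopropyl on an amide-type nitrogen in a ring. Among the measured compounds shown here, no measured step exchanges one nitrogen substituent for another, so the one step bears on it only loosely. Compound 3 is therefore expected close to the number just shown, with an estimated step of a 1.5-fold lower number from compound 2 to compound 3 (0.16 log units; within the scatter) and an estimate of 15000 nM, from 5000 nM to 40000 nM.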

Compound 3, half-maximal inhibitory concentration: 32700 nM
Compound 3: middle estimate off by 2.2-fold (0.34 log units), on the low side, within the range that was stated.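

With a 1.5-fold higher number from compound 2 to compound 3 (0.18 log units; within the scatter), 4-methoxyphenyl and cyclopropyl on the amide-type nitrogen in a ring are not told apart in this assay, although the two groups differ in ring type, heavy atoms and hydrogen-bond acceptors. Against the amide hydrogen, an at least 1.2-fold lower number from compound 1 to compound 3 (0.08 log units; that floor lies within the scatter) gives only a floor, set by a limit and not by a number: the limit of > 40000 nM in this assay, at which 1 of the 3 values shown sits.

Open, from the compounds shown here alone, is how a chain ending in an amine or a carboxylic acid on this nitrogen would read. Also open, going by these compounds, is whether any group here gives a step beyond the scatter.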